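The source may report more compounds than this note shows. Statements on the series, on what has been measured and on what is new or still open speak of the compounds shown alone.

Working notes on the series in an assay on isolated protein (strain Sprague-Dawley) for inhibition of Amine oxidase [flavin-containing] A (Rattus norvegicus), read by spectrophotometry, with a stated time of 5 min, tested at 10 uM; a higher number here means more inhibition at the concentration tested (going by the name of the read-out), a lower number less inhibition. Compound 1 `CCOc1cc(=O)oc2cc(OCc3cccc(Cl)c3)ccc12` gives 2%. Compound 2 `COCOc1cc(=O)oc2cc(OCc3cccc(Cl)c3)ccc12` gives 23%, and compound 3 `CC(=O)COc1cc(=O)oc2cc(OCc3cccc(Cl)c3)ccc12` gives 22%. Two of the measured steps are beyond the scatter: a number 21 percentage points higher from compound 1 to compound 2 (beyond the scatter) and a number 20 percentage points higher from compound 1 to compound 3 (beyond the scatter). The third is not: a number 1 percentage points lower from compound 2 to compound 3 (within the scatter). On these numbers compound 3 stands second highest of the three; its nearest neighbour is compound 2, within the scatter, and its furthest is compound 1, beyond the scatter.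

Compound 4 `CCOC(=O)COc1cc(=O)oc2cc(OCc3cccc(Cl)c3)ccc12` differs from compound 3 in one place: ethoxy in place of methyl on a carbonyl carbon. Of the measured steps, the one that bears most directly on this change is a number 1 percentage points lower from compound 2 to compound 3 (within the scatter), in which two different groups on the saturated chain carbon bound to an oxygen on the aromatic ring gave numbers within the scatter of each other. The two larger steps, a number 21 percentage points higher from compound 1 to compound 2 (beyond the scatter) and a number 20 percentage points higher from compound 1 to compound 3 (beyond the scatter), both start from the methyl of compound 1 and are not repeated here, since compound 4 keeps a carbonyl on that chain. No step beyond the scatter is therefore expected in this assay from compound 3 to compound 4; the expected step is no change at the digits printed from compound 3 to compound 4 (within the scatter). Compound 4 is thus estimated at 22%, in a range from 8% to 38%.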

Compound 4, a percentage reported as inhibition, at one concentration (the size of the read-out at that concentration, not a potency): 0%
Beside the measured number, compound 4's estimate is 22 percentage points above it, outside the stated range (below it).
By their numbers in this assay, from the lowest: compounds 4 and 1 (each within the scatter of the next); then compounds 3 and 2 (each within the scatter of the next).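

In this assay the carbonyl carbon of this chain proves sensitive to what it carries: ethoxy in place of methyl there gives a clear loss (a number 22 percentage points lower from compound 3 to compound 4 (beyond the scatter)), so keeping a carbonyl on the chain does not by itself keep the number. The ethoxycarbonyl group also separates from the methoxy of compound 2 (a number 23 percentage points lower from compound 2 to compound 4 (beyond the scatter)), yet it cannot be told apart from the methyl of compound 1 (a number 2 percentage points lower from compound 1 to compound 4 (within the scatter)), which places compound 4 with compound 1 and leaves compounds 2 and 3 as the pair with the higher numbers. Nothing at hand accounts for the difference between the acetyl and ethoxycarbonyl groups at this position.

Still open, going by these compounds, is whether the low number follows the ethoxy group as a whole or only its ethyl part; a methoxy, an amine or a hydroxyl on the same carbonyl carbon, the last giving a carboxylic acid, would separate these possibilities. Also open, on these data alone, is whether a longer chain between the ring oxygen and the carbonyl would change the reading at this concentration.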